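The source may hold more compounds than are shown below. What is called first, only, known or untested is meant among the compounds shown, and "the series" means these compounds.

Measured in a functional assay on a cell-free system (plasma, Oryctolagus cuniculus) for inhibition, with stated times of 5 min, 1 min and 6 min; on this read-out lower numbers stand for stronger inhibition and higher numbers for weaker inhibition:
- compound 1 `CCOC(=O)c1c(C)nc(-c2cccc(C#N)c2)n1C(C)C`: 9260 nM
- compound 2 `CCOCCOn1c(-c2cccc(C#N)c2)nc(C)c1C(=O)OCC`: 6250 nM
- compound 3 `CCOC(=O)c1c(C)nc(-c2cccc(C#N)c2)n1OCCCO`: 11400 nM

Compound 3, at 11400 nM, cannot be told apart from the other two: a 1.2-fold higher number from compound 1 to compound 3 (0.09 log units; within the scatter), and a 1.8-fold higher number from compound 2 to compound 3 (0.26 log units; within the scatter). The next compound, compound 4 `CCOC(=O)c1c(C)nc(-c2cccc(C#N)c2)n1OCc1ccccc1Cl`, differs from compound 3 by 2-chlorophenyl in place of 2-hydroxyethyl on a saturated chain carbon bound to an oxygen on an aromatic ring. Going by the values given here, no measured compound carries a 2-chlorophenyl group, so the evidence is indirect. Changing the group at this end of the molecule has so far moved little, as a 1.5-fold lower number from compound 1 to compound 2 (0.17 log units; within the scatter) also shows. A step beyond the scatter is therefore not expected in this assay, and the estimated step is a 1.6-fold lower number from compound 3 to compound 4 (0.21 log units; within the scatter). For compound 4 the expected value is 7000 nM, with an estimated range of 2500 nM to 20000 nM.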

Compound 4, half-maximal inhibitory concentration: 8710 nM
Beside the measured number, compound 4's estimate is 1.2-fold (0.09 log units) below it, and the stated range covers the measured number.
By their numbers in this assay, from the lowest: compounds 2, 4, 1 and 3 (each within the scatter of the next).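

In this assay, replacing 2-hydroxyethyl, which has a hydrogen-bond donor and acceptor, with 2-chlorophenyl, which has neither, gives a 1.3-fold lower number from compound 3 to compound 4 (0.12 log units; within the scatter). The comparisons with the other two compounds give a 1.4-fold higher number from compound 2 to compound 4 (0.14 log units; within the scatter) and a 1.1-fold lower number from compound 1 to compound 4 (0.03 log units; within the scatter), so even a six-membered aromatic ring at this place leaves compound 4 indistinguishable from the other three compounds. No measurement here explains this lack of separation. On these data alone, whether an amine or a carboxylic acid on this chain would produce a step beyond the scatter remains open. So does the result for a plain benzyl group without the chlorine.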